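This account rests on a few compounds, and the source may have more. Where it says the series, first, only, none or still open, it means among the compounds named here.

Measured in a functional assay on MDA-MB-231 cells (Homo sapiens) for inhibition, read by sulforhodamine B assay, with a stated time of 74 h; on this read-out lower numbers stand for stronger inhibition and higher numbers for weaker inhibition:
Compound 1 (`CS(=O)(=O)N1C(=O)COC12C=CC(=O)C=C2`): > 10000 nM (a limit)
Compound 2 (`O=C1C=CC2(C=C1)OCC(=O)N2S(=O)(=O)c1ccccc1`): > 10000 nM (a limit)
Compound 3 (`O=C1C=CC2(C=C1)OCC(=O)N2S(=O)(=O)c1cccs1`): 20 nM

For the measured compounds named here, compound 3 is the only compound with a number, 20 nM in this assay. The rest of the series sits at the limit of > 10000 nM in this assay, at which 2 of the 3 values shown sit.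

Compound 4 (`O=C1C=CC2(C=C1)OCC(=O)N2S(=O)(=O)c1ccc(Br)s1`) differs from compound 3 in one place: bromo in place of hydrogen on an aromatic carbon. This is bromo in place of hydrogen on an aromatic carbon, turning thiophen-2-yl into 5-bromothiophen-2-yl.

The measured steps all concern the group on the sulfonyl sulfur. Thiophen-2-yl in place of methyl gave an at least 500-fold lower number from compound 1 to compound 3 (2.69 log units; beyond the scatter), and thiophen-2-yl in place of phenyl gave an at least 500-fold lower number from compound 2 to compound 3 (2.69 log units; beyond the scatter), both large. Phenyl in place of methyl gave a step that the two limits leave unreadable from compound 1 to compound 2. None of these is a substitution on the thiophen-2-yl group itself, so they set no size for this change. They do show that the number can move sharply with this group, so the range is kept wide, mainly towards weaker inhibition.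

No clear shift beyond the scatter is expected, and the expected step is a 1.5-fold higher number from compound 3 to compound 4 (0.18 log units; within the scatter). The estimate for compound 4 is 30 nM, with an expected range from 6 nM to 200 nM.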

Compound 4, half-maximal inhibitory concentration: > 10000 nM
Compound 4 ended at the assay's limit; the forecaster's own chance of this, stated with the estimate: 8%; middle value at least 330-fold (2.52 log units) away from the limit.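

Bromo in place of hydrogen on an aromatic carbon, next to the ring sulfur, gives an at least 500-fold higher number from compound 3 to compound 4 (2.69 log units; beyond the scatter) in this assay, the first size set for a substitution on the thiophen-2-yl group itself. The number of compound 3 therefore depends not only on having thiophen-2-yl on the sulfonyl sulfur but also on this position carrying hydrogen, and compound 3 remains alone with a number: the limit of > 10000 nM in this assay, at which 3 of the 4 values shown sit. The steps to compound 4 from compound 1 and compound 2 cannot be read, since both ends of each are limits.

Going by these compounds, it remains open whether this shift belongs to bromo alone or to any group at this position, which fluoro, methyl or an amine there would help separate. The compounds shown also leave open how a methoxy group elsewhere on the thiophen-2-yl ring would behave.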